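The source may report more compounds than this note shows. Statements on the series, on what has been measured and on what is new or still open speak of the compounds shown alone.

Compound 1 `CN1CCC(c2ccc(OCc3ccccc3)c(C(=O)Nc3ccnnc3)c2)CC1` gives 71000 nM in a physicochemical assay for solubility, measured as kinetic solubility; a higher number here means a more soluble compound, a lower number a less soluble compound.
Compound 2 `O=C(Nc1ccnnc1)c1cc(N2CCC(CO)CC2)ccc1OCc1ccccc1` gives 323000 nM in this assay.

Among the compounds with values here, compound 2 stands highest of the two numbers in this assay; the single measured step is a 4.5-fold higher number from compound 1 to compound 2 (0.66 log units; beyond the scatter), a modest one. Compound 3 `O=C(Nc1ccnnc1)c1cc(C(F)(F)F)ccc1OCc1ccccc1` is not yet measured. It differs from compound 2 in one place: trifluoromethyl in place of 4-(hydroxymethyl)piperidin-1-yl on an aromatic carbon. Within the data shown here, only that one step bears on this change, and it involved the same position but not the trifluoromethyl, so the data reach only a short way. A downward step of about that size is expected, an 8.1-fold lower number from compound 2 to compound 3 (0.91 log units; beyond the scatter). Compound 3 is expected at 40000 nM, in the range 8000 nM to 150000 nM in this assay.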

Compound 3, solubility: < 1000 nM
Compound 3 gave a limit, no number; the forecaster's own chance of this, stated with the estimate: 10%; at least 40-fold (1.60 log units) between middle value and limit.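

In this assay compound 3 stands at a limit of the assay and not at a number: the limit of < 1000 nM in this assay, at which 1 of the 3 values shown sits. Putting trifluoromethyl at this position gives two large steps (an at least 320-fold lower number from compound 2 to compound 3 (2.50 log units; beyond the scatter)) and (an at least 71-fold lower number from compound 1 to compound 3 (1.85 log units; beyond the scatter)). The earlier step (a 4.5-fold higher number from compound 1 to compound 2 (0.66 log units; beyond the scatter)) was only modest and ran between two groups that each carry a six-membered non-aromatic ring, so the position proves far more sensitive to this change than that step showed.

From the compounds shown here alone, the true size of both new steps stays open. So does whether a small amine, a carboxylic acid or a short ether chain here would fall nearer compound 2 or compound 3.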